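The source may hold more compounds than are shown below. What is called first, only, known or untested is meant among the compounds shown, and "the series" means these compounds.

Measured so far:
- compound 1, `COc1ccc(Cl)cc1S(=O)(=O)Nc1cncc(C(=O)Nc2ccccc2)c1`: 310 nM
- compound 2, `COc1ccc(F)cc1S(=O)(=O)Nc1cncc(C(N)=O)c1`: 19 nM

Both compounds were tested in an assay on isolated protein for inhibition of alkaline phosphatase, tissue-nonspecific isozyme (Homo sapiens); a higher number here means a weaker inhibitor, a lower number a stronger inhibitor. Compound 1 gives 310 nM, the highest of the two numbers, and so the weaker inhibitor of the pair. Compound 2 differs from compound 1 in several places, not in one alone. Compound 2 gives 19 nM, and the gap between the two numbers lies beyond the usual scatter. Within the data shown here, no single-change step between measured compounds is available, so nothing can be said about what any one change alone does.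

Compound 3, `COc1ccc(Cl)cc1S(=O)(=O)Nc1cncc(C(=O)N2CCN(C)CC2)c1`, has not yet been tested. It is derived from compound 1 by one change: 4-methylpiperazin-1-yl in place of anilino on a carbonyl carbon. Compound 2 shows that a smaller amide than the anilide of compound 1 can go with a lower number, but it carries a second difference as well, so it is only a loose guide. The step of a 1.2-fold lower number from compound 1 to compound 3 (0.09 log units; within the scatter) is expected to be small, with no clear direction beyond the scatter. Compound 3 is therefore estimated at 250 nM, within a range from 60 nM to 1000 nM.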

Compound 3, half-maximal inhibitory concentration: 671 nM
Compound 3: middle estimate off by 2.7-fold (0.43 log units), on the low side; low and high end bracket the measured number.
By their numbers in this assay, from the lowest: compound 2; then compound 1; then compound 3.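

In this assay, among these compounds, 4-methylpiperazin-1-yl in place of anilino on a carbonyl carbon gives a 2.2-fold higher number from compound 1 to compound 3 (0.34 log units; beyond the scatter), the first single-change step and a modest one, so the group at this place does affect the number. Both groups have 7 heavy atoms, which shows that a group's heavy-atom count alone does not set the number here, but the swap also removes a ring of carbon only and the amide hydrogen while bringing in a non-aromatic ring with 2 hetero atoms, so this one step cannot separate those differences. No measurement shown here explains the rise in the number.

On these data alone, what remains open is which of those differences matters: cyclohexylamino on the same carbonyl carbon would keep the amide hydrogen without the aromatic ring, while piperidin-1-yl would give a non-aromatic ring without the second ring nitrogen. Compound 2 differs from compound 1 in several places, so its lower number cannot be assigned to the smaller amide or to the fluoro group in place of chloro.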